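Swapping 2-nitrophenyl for 4-nitrophenyl: what to expect

A few compounds are considered here, and "the series" means these few. Any claim that something is new, unique, unknown or untested is made for them only; others in the source may bear on it.

In a functional assay on UACC-62 cells (Homo sapiens) for cytotoxicity, read by sulforhodamine B assay (on this read-out lower numbers stand for stronger inhibition of growth and higher numbers for weaker inhibition of growth), compound 1 `CC1=CC[C@@H]([C@@](C)(O)CCCC(C)(C)NC(=S)N/N=C\c2ccccc2)CC1` gives 43800 nM as its number, compound 2 `CC1=CC[C@@H]([C@@](C)(O)CCCC(C)(C)NC(=S)N/N=C\c2ccc(C)cc2)CC1` gives 39000 nM and compound 3 `CC1=CC[C@@H]([C@@](C)(O)CCCC(C)(C)NC(=S)N/N=C\c2ccccc2[N+](=O)[O-])CC1` gives 16600 nM as the lowest of the three. Compound 3 is therefore the strongest growth inhibitor so far, and its steps to both others lie beyond the scatter.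

Compound 4 `CC1=CC[C@@H]([C@@](C)(O)CCCC(C)(C)NC(=S)N/N=C\c2ccc([N+](=O)[O-])cc2)CC1` has 4-nitrophenyl in place of 2-nitrophenyl on a carbon with a double bond to nitrogen. For the measured compounds named here, no measured compound carries this exact group, so the closest guides are indirect. Nitro in place of hydrogen gave a 2.6-fold lower number from compound 1 to compound 3 (0.42 log units; beyond the scatter) as a modest step, and the swap to 2-nitrophenyl gave a 2.3-fold lower number from compound 2 to compound 3 (0.37 log units; beyond the scatter) as a similar one. Methyl in place of hydrogen gave only a 1.1-fold lower number from compound 1 to compound 2 (0.05 log units; within the scatter) as its step.

Compound 4 keeps a nitro group, so it is expected to stay close to compound 3, perhaps with a slightly higher number. The expected change is a 1.3-fold higher number from compound 3 to compound 4 (0.10 log units; within the scatter) and should stay within the scatter. Compound 4 is estimated at 21000 nM with an expected range from 10000 nM to 42000 nM on this read-out.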

Compound 4, concentration for total growth inhibition: 62200 nM
Compound 4: middle estimate off by 3.0-fold (0.47 log units), on the low side, and the stated range ends below it.
By their numbers in this assay, from the lowest: compound 3; then compounds 2, 1 and 4 (each within the scatter of the next).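

In this assay the place of the nitro group counts, even though compound 3 and compound 4 hold the same atoms: 4-nitrophenyl in place of 2-nitrophenyl gives a clear step (a 3.7-fold higher number from compound 3 to compound 4 (0.57 log units; beyond the scatter)). The earlier gain therefore goes with 2-nitrophenyl and not with any nitro group on the ring, as 4-nitrophenyl stands within the scatter of both the unsubstituted phenyl (a 1.4-fold higher number from compound 1 to compound 4 (0.15 log units; within the scatter)) and 4-methylphenyl (a 1.6-fold higher number from compound 2 to compound 4 (0.20 log units; within the scatter)). Nothing available here explains why the two nitrophenyl groups differ.

Going by these compounds, it stays open whether the lower number of compound 3 is special to nitro, or whether an amine or a nitrile in place of that nitro group would give a similar one. On these data alone, the effect of changes to the long chain carrying the hydroxyl group also stays open.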